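A 4-methylphenyl in place of 3-cyanophenyl

The source may hold more compounds than are shown below. What is called first, only, known or untested is meant among the compounds shown, and "the series" means these compounds.

In a functional assay on HepG2 cells (Homo sapiens) for cytotoxicity, read by MTT assay, with a stated time of 72 h (on this read-out higher numbers stand for weaker inhibition and lower numbers for stronger inhibition), compound 1 (`Cc1ccc(S(=O)(=O)OCCCc2cn(-c3ccc(C(F)(F)F)cc3)nn2)cc1`) gives 42600 nM as its measured number. Compound 2 (`COC(=O)c1ccc(-n2cc(CCCOS(=O)(=O)c3ccc(C)cc3)nn2)cc1`) gives only a limit, > 100000 nM and no number. Compound 3 (`Cc1ccc(S(=O)(=O)OCCCc2cn(-c3cccc(C#N)c3)nn2)cc1`) likewise gives only a limit, > 100000 nM and no number. Compound 3 therefore stands at the limit of > 100000 nM in this assay, at which 2 of the 3 values shown sit, and offers no exact starting point.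

Compound 4 (`Cc1ccc(-n2cc(CCCOS(=O)(=O)c3ccc(C)cc3)nn2)cc1`) differs from compound 3 by 4-methylphenyl in place of 3-cyanophenyl on an aromatic nitrogen and carries 4-methylphenyl in place of 3-cyanophenyl on an aromatic nitrogen. Within the data shown here, no measured step makes this same change. The nearest evidence is an at least 2.3-fold higher number from compound 1 to compound 2 (0.37 log units; beyond the scatter) and it shows that a change on this aromatic group can move the number beyond the scatter.

With compound 3 at > 100000 nM as a limit, only a move towards a lower number could be seen in this assay and a small one is expected, possibly none beyond the scatter. The estimate for compound 4 is 80000 nM (expected range 30000 nM to 150000 nM) and a limit is about as likely as a number. This estimate means an expected at least 1.2-fold lower number from compound 3 to compound 4 (0.09 log units; that floor lies within the scatter) in all.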

Compound 4, half-maximal inhibitory concentration: > 100000 nM
Compound 4 was reported as a limit (the forecaster's own chance of this, stated with the estimate: 50%); middle value at least 1.2-fold (0.09 log units) from the limit.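

In this assay, the steps from compound 3 to compound 4 and from compound 2 to compound 4 cannot be read, as each joins two limits. Methyl in place of trifluoromethyl on an aromatic carbon gives an at least 2.3-fold higher number from compound 1 to compound 4 (0.37 log units; beyond the scatter), a second replacement of trifluoromethyl that ends at a limit, after methoxycarbonyl. Trifluoromethyl is thus the only group shown on this aromatic ring that gives a measured number, and the limit now holds most of the set: the limit of > 100000 nM in this assay, at which 3 of the 4 values shown sit.

Going by these compounds, how the compounds at the limit rank against one another stays open. On these data alone, it is also open whether a chlorine atom or an amine in place of trifluoromethyl would give a measured number, and what a longer chain between the two ends of the shared core would do.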